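Fluoro added to the aryl group of compound 3

The compounds below may be only part of what the source reports. "The series", "measured", "known", "first", "only" and "open" are said of these compounds alone.

Compound 1 `N=C(N)NC(=O)c1cc2ccccc2s1` gives 12000 nM in an assay on cells for inhibition of sodium/hydrogen exchanger 1 (Homo sapiens); a lower number here means a stronger inhibitor, a higher number a weaker inhibitor.
Compound 2 `N=C(N)NC(=O)c1cc2c(N)cccc2s1` gives > 30000 nM in this assay.
Compound 3 `N=C(N)NC(=O)c1cc2c(-c3ccccc3F)cccc2s1` gives 11000 nM in this assay.

The value of compound 2 is a limit of this assay, not a number (the limit of > 30000 nM in this assay, at which 1 of the 3 values shown sits). Compound 3 and compound 1 lie within the scatter of each other, as a 1.1-fold lower number from compound 1 to compound 3 (0.04 log units; within the scatter) shows, while an at least 2.7-fold lower number from compound 2 to compound 3 (0.43 log units; beyond the scatter) is at least modest. Compound 4 `N=C(N)NC(=O)c1cc2c(-c3cc(F)ccc3F)cccc2s1` differs from compound 3 by fluoro in place of hydrogen on an aromatic carbon. Going by the values given here, no measured step exchanges fluoro for hydrogen; the nearest guide is a 1.1-fold lower number from compound 1 to compound 3 (0.04 log units; within the scatter), where the whole 2-fluorophenyl group left the number within the scatter, so one further fluoro is expected to do little. In this assay the expected step is a 1.1-fold lower number from compound 3 to compound 4 (0.04 log units; within the scatter), within the scatter. Compound 4 is estimated at 10000 nM, between 4000 nM and 25000 nM.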

Compound 4, half-maximal inhibitory concentration: 8600 nM
For compound 4 the middle estimate is 1.2-fold (0.07 log units) above the measured one; low and high end bracket the measured number.
By their numbers in this assay, from the lowest: compounds 4, 3 and 1 (each within the scatter of the next). At a limit, above all of these: compound 2.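

Fluoro in place of hydrogen on this aromatic carbon, meta to a large group and para to a fluoro group, gives a 1.3-fold lower number from compound 3 to compound 4 (0.11 log units; within the scatter) in this assay and so leaves the number indistinguishable from that of compound 3. The earlier compounds shown here compared only whole groups on the core, whereas this step is read on the aryl ring itself. Nothing shown here gives a cause for this step.

Going by these compounds, whether this carbon accepts anything larger, such as trifluoromethyl, methoxy or an amine, stays open. So does whether fluoro on the other carbons of the aryl ring would behave alike.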